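Replacing the amino group of compound 2

The source may hold more compounds than are shown below. What is called first, only, known or untested is meant among the compounds shown, and "the series" means these compounds.

In an ADME assay on CHO cells (Cricetulus griseus) for cytotoxicity, read by MTT assay (on this read-out lower numbers stand for higher toxicity in this test and higher numbers for lower toxicity in this test), compound 1 (`Fc1ccc(-c2nc3c(N4CCNCC4)nccc3[nH]2)cc1F`) gives 8100 nM and compound 2 (`NC1CCN(c2nccc3[nH]c(-c4ccc(F)c(F)c4)nc23)CC1`) gives 8200 nM. Among the compounds with values here, these are the only two numbers so far, and they lie within the scatter of each other, so compound 2 does not stand apart from compound 1. Within the data shown here, the one measured step is a 1.0-fold higher number from compound 1 to compound 2 (0.01 log units; within the scatter), with 4-aminopiperidin-1-yl in place of piperazin-1-yl on an aromatic carbon.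

Compound 3 (`CN1CCN(C2CCN(c3nccc4[nH]c(-c5ccc(F)c(F)c5)nc34)CC2)CC1`) has 4-methylpiperazin-1-yl in place of amino on a saturated ring carbon. Among the measured compounds shown here, no measured step covers a change at this place, so the evidence is indirect. Judging from compound 2 and its step of a 1.0-fold higher number from compound 1 to compound 2 (0.01 log units; within the scatter), no shift beyond the scatter is expected in this assay. The estimated step is a 1.3-fold lower number from compound 2 to compound 3 (0.10 log units; within the scatter). For compound 3 the estimated value is 6500 nM, with an expected range from 2500 nM to 16000 nM. The range is kept wide, as a single step is a thin basis for so large a change.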

Compound 3, half-maximal cytotoxic concentration: 5000 nM
Compound 3: the middle estimate sits 1.3-fold (0.11 log units) above what was measured, within the range that was stated.
By their numbers in this assay, from the lowest: compounds 3, 1 and 2 (each within the scatter of the next).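

At the saturated ring carbon, three ring bonds from the ring nitrogen, 4-methylpiperazin-1-yl in place of amino gives a 1.6-fold lower number from compound 2 to compound 3 (0.21 log units; within the scatter) in this assay. Within the data shown here, this is the first measured change at this place, and it shows that amino can give way to a much larger group, one that brings a second six-membered non-aromatic ring and has no hydrogen-bond donors, with the read-out staying within the scatter of compound 2. This rests on a single pair, compound 2 and compound 3, and no measurement at hand speaks to the reason for the result.

Open, from the compounds shown here alone, is whether other groups on this carbon, such as a hydroxyl, a dimethylamino group or a carboxylic acid, would also stay within the scatter of compound 2. Also open, going by these compounds, is whether the same exchange reads alike on a core carrying other substituents, since compound 2 and compound 3 share a single core and the step is known only in this one read-out.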